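The compounds below may be only part of what the source reports. "The series", "measured", "known", "first", "only" and "open" are said of these compounds alone.

Measured in an ADME assay on Vero cells (Chlorocebus sabaeus) for cytotoxicity, read by MTT assay; a lower number here means that less compound is tolerated, a higher number that more compound is tolerated:
- Compound 1 `CCn1nc(C(F)(F)F)cc1C(=O)Nc1ccc(S(=O)(=O)N2CCCCC2C)cc1`: 30000 nM
- Compound 2 `Cn1nc(C(F)(F)F)cc1C(=O)Nc1ccc(S(=O)(=O)N2CCC[C@H]2C(=O)OC(=O)c2ccccc2)cc1`: 100000 nM
- Compound 3 `Cn1nc(C(F)(F)F)cc1C(=O)Nc1ccc(S(=O)(=O)N2CCC(C(F)(F)F)CC2)cc1`: 159000 nM

Compound 3 gives 159000 nM and compound 2 gives 100000 nM. These two values lie within the usual scatter of each other. Compound 1 gives 30000 nM. The gap between compound 1 and compound 3 is larger than the usual scatter, with compound 3 the higher of the two. Compound 4 `Cn1nc(C(F)(F)F)cc1C(=O)Nc1ccc(S(=O)(=O)N2CCC(N)CC2)cc1` has amino in place of trifluoromethyl on a saturated ring carbon. Among the compounds with values here, no two measured compounds differ in one place, so the data offer no direct precedent for this change. Within the data shown here, the only guide is the spread of the three measured values in this assay. A downward move of modest size, close to the scatter, is expected, an estimated 1.8-fold lower number from compound 3 to compound 4 (0.25 log units; within the scatter). For compound 4 the estimated value is 90000 nM, with an expected range from 25000 nM to 250000 nM.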

Compound 4, half-maximal cytotoxic concentration: > 300000 nM
Compound 4: only a limit was reported (the forecaster's own chance of this, stated with the estimate: 15%); middle value at least 3.3-fold (0.52 log units) from the limit.
By their numbers in this assay, from the lowest: compound 1; then compounds 2 and 3 (each within the scatter of the next). At a limit, above all of these: compound 4.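

Within the data shown here, the step from trifluoromethyl to amino on this saturated ring carbon is the first one-place change in this set, and it reads an at least 1.8-fold higher number from compound 3 to compound 4 (0.27 log units; that floor lies within the scatter) in this assay. Swapping 4-(trifluoromethyl)piperidin-1-yl for 4-aminopiperidin-1-yl therefore brought no loss in the concentration tolerated, although the floor of that step stays within the scatter. Compound 4 has a limit of the assay and not a number: the limit of > 300000 nM in this assay, at which 1 of the 4 values shown sits.

From the compounds shown here alone, how far the true value of compound 4 lies past that limit remains open. So does whether a carboxylic acid, a methylamino group or a longer chain at this ring carbon would read like amino or like trifluoromethyl.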